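Imidazole in Place of Dioxopyrrolidine: Cytotoxicity Outlook

A few compounds are considered here, and "the series" means these few. Any claim that something is new, unique, unknown or untested is made for them only; others in the source may bear on it.

Measured compounds, in an ADME assay on L02 cells (Homo sapiens) for cytotoxicity, read by MTT assay, with a stated time of 48 h; on this read-out lower numbers stand for stronger inhibition and higher numbers for weaker inhibition:
Compound 1 `COC(=O)CC1CCN(C[C@H]2CN(c3ccc(-n4cc(-c5ccccn5)cn4)c(F)c3)C(=O)O2)CC1`: > 400 ug/mL, a limit of the assay
Compound 2 `O=C1O[C@@H](CN2CCC(c3ccc(F)cc3)CC2)CN1c1ccc(-n2cc(-c3ccccn3)cn2)c(F)c1`: > 400 ug/mL, a limit of the assay
Compound 3 `O=C1CCC(=O)N1C[C@H]1CN(c2ccc(-n3cc(-c4ccccn4)cn3)c(F)c2)C(=O)O1`: > 400 ug/mL, a limit of the assay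

None of the three readings in this assay is a number; each is only a limit, meaning no inhibition of the liver cells was seen up to the highest concentration tested. Compound 3 therefore stands at the limit of > 400 ug/mL in this assay, at which 3 of the 3 values shown sit, together with the two other compounds. Two steps between measured compounds exist, but neither can be sized: a step that the two limits leave unreadable from compound 1 to compound 2 and a step that the two limits leave unreadable from compound 1 to compound 3 run from one limit to another, so they say nothing about direction or magnitude.

Compound 4 `O=C1O[C@@H](Cn2ccnc2)CN1c1ccc(-n2cc(-c3ccccn3)cn2)c(F)c1` differs from compound 3 in one place: 1H-imidazol-1-yl in place of 2,5-dioxopyrrolidin-1-yl on a saturated chain carbon bound to a saturated ring carbon. Going by the values given here, no measured step bears on this change in a readable way, and the only evidence is that every compound sharing this core has so far stayed at the limit. The expectation is therefore that the step that the limit leaves unreadable from compound 3 to compound 4 shows no change beyond the scatter, with compound 4 most likely again reported as a limit.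

Compound 4 is estimated at 450 ug/mL in this assay, with a range from 150 ug/mL to 1000 ug/mL.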

Compound 4, half-maximal inhibitory concentration: 350 ug/mL
Compound 4: middle estimate off by 1.3-fold (0.11 log units), on the high side, and the stated range covers the measured number.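

Compound 4 gives the first reading in this assay that is a number rather than a limit, while the other compounds all remain limits, and the steps among those limits cannot be read: the limit of > 400 ug/mL in this assay, at which 3 of the 4 values shown sit.

Putting 1H-imidazol-1-yl in place of 2,5-dioxopyrrolidin-1-yl on a saturated chain carbon bound to a saturated ring carbon gives an at least 1.1-fold lower number from compound 3 to compound 4 (0.05 log units; that floor lies within the scatter), and putting the same group in place of 4-((methoxycarbonyl)methyl)piperidin-1-yl gives an at least 1.1-fold lower number from compound 1 to compound 4 (0.05 log units; that floor lies within the scatter). Both figures are only floors, so they show no real difference yet, but they do show that a change at this position can yield a reading that is a number, which gives later compounds a value to be compared with.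

As far as these compounds go, how far the true values of compound 1 and compound 3 lie beyond their limits remains open, and with it the real size of these two steps. Also open, from the compounds shown here alone, is whether a carboxylic acid or a 1H-1,2,4-triazol-1-yl group at the same place would give a number, as compound 4 does, or would stay at the limit.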